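This account rests on a few compounds, and the source may have more. Where it says the series, first, only, none or still open, it means among the compounds named here.

Measured compounds:
compound 1 `Cc1nc(-c2cccc(C(=O)N3CCCC(C(=O)Nc4ccc(Cl)cc4)C3)c2)no1` — 0%
compound 2 `O=C(c1ccccc1)c1cccc(NC(=O)C2CCCN(C(=O)c3cc(C(F)(F)F)cc(C(F)(F)F)c3)C2)c1` — 0%

In an ADME assay on PC-3 cells (Homo sapiens) for cytotoxicity, read by WST assay, tested at 100 uM (on this read-out lower numbers stand for less inhibition and higher numbers for more inhibition at the one concentration tested (going by the name of the read-out)), compound 1 gives 0%, and in this assay compound 2 gives 0%; the two values are level at the digits shown, within the scatter, so neither can be called the more or less toxic of the pair.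

Compound 3 `COCc1cccc(C(=O)N2CCCC(C(=O)Nc3ccc(Cl)cc3)C2)c1` is not yet measured in this assay. It differs from compound 1 in one place: methoxymethyl in place of 5-methyl-1,2,4-oxadiazol-3-yl on an aromatic carbon. Both measured compounds show no inhibition, and a change of this kind gives no grounds to expect otherwise, so the step of no change at the digits printed from compound 1 to compound 3 (within the scatter) is expected to be none beyond the scatter. Compound 3 is estimated at 0%, with a range from -8% to 12%.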

Compound 3, a percentage reported as inhibition, at one concentration (the size of the read-out at that concentration, not a potency): 0%
Beside the measured number, compound 3's estimate shows no gap at the digits printed; low and high end bracket the measured number.
By their numbers in this assay, from the lowest: compounds 1, 2 and 3 (each within the scatter of the next).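

In this assay, putting methoxymethyl in place of 5-methyl-1,2,4-oxadiazol-3-yl on the aromatic carbon gives no change at the digits printed from compound 1 to compound 3 (within the scatter). Within the data shown here, this is the first single change that can be read at this position: a five-membered aromatic ring with 3 hetero atoms gives way to a group with no ring and fewer heavy atoms, and the read-out does not shift. Nothing on hand accounts for this result. The compounds shown leave open whether an amine or a carboxylic acid at this position would shift the read-out.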